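Nitro-to-chloro exchange on a dienone series, working notes

The source may hold more compounds than are shown below. What is called first, only, known or untested is meant among the compounds shown, and "the series" means these compounds.

compound 1, `O=C(/C=C/c1ccc(Oc2ncnc3ccc(Cl)cc23)cc1)/C=C/c1cc([N+](=O)[O-])ccc1Cl`: 3150 nM
compound 2, `O=C(/C=C/c1ccc(Cl)c([N+](=O)[O-])c1)/C=C/c1ccccc1Oc1ncnc2ccc(Cl)cc12`: 9760 nM

Among the measured compounds shown here, both compounds have been read in a functional assay on PC-3 cells (Homo sapiens) for inhibition, read by MTT assay, with a stated time of 72 h; a higher number here means a weaker inhibitor, a lower number a stronger inhibitor. Compound 2 gives the higher of the two numbers, 9760 nM. Compound 1 gives 3150 nM, and the gap between the two lies beyond the scatter, so compound 2 is the weaker of the pair. For the measured compounds named here, the two compounds differ in more than one place at once, so no single step can be drawn between them, and only their two values can be compared.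

Compound 3, `O=C(/C=C/c1ccc(Cl)c(Cl)c1)/C=C/c1ccccc1Oc1ncnc2ccc(Cl)cc12`, is not yet measured. It differs from compound 2 in that (chloro in place of nitro on an aromatic carbon). Nothing in the measured pair isolates this change, so no direction can be read from the data. The expected step is small, estimated as a 1.2-fold lower number from compound 2 to compound 3 (0.09 log units; within the scatter), not beyond the scatter in either direction. For compound 3 the estimate in this assay is 8000 nM, within a range from 3000 nM to 20000 nM.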

Compound 3, half-maximal inhibitory concentration: 18300 nM
Compound 3: middle estimate off by 2.3-fold (0.36 log units), on the low side; the range from low to high includes it.
By their numbers in this assay, from the lowest: compound 1; then compounds 2 and 3 (each within the scatter of the next).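

In this assay, among the compounds shown here, the step of a 1.9-fold higher number from compound 2 to compound 3 (0.27 log units; within the scatter) is the first comparison that changes one place only, from 4-chloro-3-nitrophenyl to 3,4-dichlorophenyl. The step stays within the scatter, so compound 2 and compound 3 cannot be told apart, and in this pair the nitro group on this aromatic carbon, ortho to a chloro group, is not shown to be required for the activity read here. No measured property of either group is available to account for this result.

Going by these compounds, whether an amine or a methoxy group in the same place would read differently remains open. Also open, on these data alone, is whether chloro in place of nitro would give a similar step on the arrangement of compound 1, which gives the lowest number so far.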